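From Trifluoromethyl to Phenoxy: Estimating Compound 4

The compounds below may be only part of what the source reports. "The series", "measured", "known", "first", "only" and "open" are said of these compounds alone.

Compound 1 `Cc1n[nH]c(C(=O)O)c1Cc1ccc2ccccc2n1` gives 18% in an assay on isolated protein for inhibition of 2-Hydroxyacid oxidase 2 (Homo sapiens), tested at 10 uM; on this read-out lower numbers stand for a weaker effect and higher numbers for a stronger effect at the one concentration tested.
Compound 2 `Cc1n[nH]c(C(=O)O)c1Cc1ccccc1-c1ccc(F)cc1` gives 56% in this assay.
Compound 3 `Cc1n[nH]c(C(=O)O)c1Cc1ccccc1C(F)(F)F` gives 38% in this assay.

Among these three numbers compound 3 stands second highest: compound 2 lies above it, beyond the scatter, and compound 1 lies below it, also beyond the scatter. Compound 4 `Cc1n[nH]c(C(=O)O)c1Cc1ccccc1Oc1ccccc1` differs from compound 3 in one place: phenoxy in place of trifluoromethyl on an aromatic carbon.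

Going by the values given here, only one measured step bears on this change. The step of a number 18 percentage points lower from compound 2 to compound 3 (beyond the scatter) shows that removing a ring-bearing group in favour of trifluoromethyl at this aromatic carbon cost a modest amount of inhibition. Compound 4 reverses that direction, bringing back a six-membered aromatic ring through an oxygen linker, so the expected step of a number 10 percentage points higher from compound 3 to compound 4 (within the scatter) is upward, of roughly the size seen between compound 2 and compound 3, though phenoxy is not the same group as 4-fluorophenyl and the return need not be complete. Compound 4 is therefore estimated at 48%, within a range from 28% to 68%.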

Compound 4, a percentage reported as inhibition, at one concentration (the size of the read-out at that concentration, not a potency): 49%
Estimate against measurement, compound 4: 1 percentage points below, within the range that was stated.
By their numbers in this assay, from the lowest: compound 1; then compound 3; then compounds 4 and 2 (each within the scatter of the next).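

Replacing trifluoromethyl with phenoxy gives a number 11 percentage points higher from compound 3 to compound 4 (beyond the scatter) in this assay and shows that an aromatic ring joined through an oxygen can also raise the read-out at this aromatic carbon. A ring attached directly is therefore not the only arrangement that reads above trifluoromethyl here. Replacing 4-fluorophenyl with phenoxy gives a number 7 percentage points lower from compound 2 to compound 4 (within the scatter) and so leaves these two ring-bearing groups indistinguishable on this read-out, although no measurement here offers a reason for any of these differences.

Still open, on these data alone, is whether the ring or the oxygen matters more, which a methoxy group (oxygen without the ring) and a benzyl group (ring with a carbon linker) could help separate. A 4-fluorophenoxy group could likewise show whether the fluorine has any bearing on the read-out when the ring is joined through oxygen.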